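The source may report more compounds than this note shows. Statements on the series, on what has been measured and on what is new or still open speak of the compounds shown alone.

Compound 1 `CCCn1c(=O)[nH]c2nc(-c3ccc(S(=O)(=O)N4CCN(c5cccc(Cl)c5)CC4)cc3)[nH]c2c1=O`: 53.5 nM
Compound 2 `CCCn1c(=O)[nH]c2nc(-c3ccc(S(=O)(=O)N4CCN(Cc5cccc(Br)c5)CC4)cc3)[nH]c2c1=O`: > 1000 nM
Compound 3 `CCCn1c(=O)[nH]c2nc(-c3ccc(S(=O)(=O)N4CCN(c5cccc(Br)c5)CC4)cc3)[nH]c2c1=O`: > 1000 nM

In an assay on CHO cells for displacement of a labelled ligand from adenosine receptor A3 (Homo sapiens), read by scintillation counting, with a stated time of 45 min, in the presence of a further agent that is not named here (on this read-out lower numbers stand for stronger inhibition and higher numbers for weaker inhibition), compound 1 gives 53.5 nM, a measured number. For compound 2 the assay returns only a limit, > 1000 nM. Compound 3 likewise stands at a limit, > 1000 nM, so it sits at the weaker end of the three with no exact number of its own; the same limit, (the limit of > 1000 nM in this assay, at which 2 of the 3 values shown sit), holds for two of the three compounds.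

Compound 4 `CCCn1c(=O)[nH]c2nc(-c3ccc(S(=O)(=O)N4CCN(c5ccccc5F)CC4)cc3)[nH]c2c1=O` differs from compound 3 by 2-fluorophenyl in place of 3-bromophenyl on an amine nitrogen in a ring. For the measured compounds named here, two measured steps bear on this part of the molecule. Changing only the halogen on that ring gave an at least 18-fold higher number from compound 1 to compound 3 (1.27 log units; beyond the scatter). Replacing the whole group on the ring nitrogen gave an at least 18-fold higher number from compound 1 to compound 2 (1.27 log units; beyond the scatter). The step that the two limits leave unreadable from compound 2 to compound 3 cannot be read from two limits. A halogen change on this ring has thus moved the number a lot once, so another halogen change is expected to matter as well. Compound 4 is expected to show an at least 3.3-fold lower number from compound 3 to compound 4 (0.52 log units; beyond the scatter), toward a lower number, with an estimated value of 300 nM and a range from 60 nM to 1500 nM.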

Compound 4, inhibition constant: > 1000 nM
Compound 4: a limit, no number; the forecaster's own chance of this, stated with the estimate: 30%; at least 3.3-fold (0.52 log units) between middle value and limit.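

A second halogen change on this ring also leaves the compound far from compound 1 in this assay: an at least 18-fold higher number from compound 1 to compound 4 (1.27 log units; beyond the scatter). This change replaces chlorine with fluorine and also moves the halogen, from the 3-position of the phenyl group to the 2-position, so a measured number has still been obtained only with 3-chlorophenyl. Compound 4 now shares the limit with compounds 2 and 3: the limit of > 1000 nM in this assay, at which 3 of the 4 values shown sit.

The steps among compounds 2, 3 and 4 cannot be read, as all three values are limits, so these compounds cannot be ranked. The compounds shown leave open whether the halogen or its place on the ring matters more, and how a plain phenyl group, or a methyl or methoxy group in place of the halogen, would behave.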